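This account rests on a few compounds, and the source may have more. Where it says the series, first, only, none or still open, it means among the compounds named here.

The measured compounds:

compound 1, `CCOC(=O)NC(=O)NC1=CS(=O)(=O)O[C@@]12[C@@H](CO[Si](C)(C)C(C)(C)C)O[C@@H](n1cc(C)c(=O)n(C)c1=O)[C@@H]2O[Si](C)(C)C(C)(C)C`, giving 14000 nM in a functional assay on HEL cells (Homo sapiens); on this read-out higher numbers stand for lower toxicity in this test and lower numbers for higher toxicity in this test
compound 2, `Cc1cn([C@@H]2O[C@H](CO[Si](C)(C)C(C)(C)C)[C@@]3(OS(=O)(=O)C=C3NCCC(N)=O)[C@H]2O[Si](C)(C)C(C)(C)C)c(=O)n(C)c1=O`, giving 14800 nM in this assay
compound 3, `Cc1cn([C@@H]2O[C@H](CO[Si](C)(C)C(C)(C)C)[C@@]3(OS(=O)(=O)C=C3NCCC(=O)O)[C@H]2O[Si](C)(C)C(C)(C)C)c(=O)n(C)c1=O`, giving 34000 nM in this assay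

Compound 3 stands at the highest number of the three. Its nearest neighbour is compound 2, with a 2.3-fold higher number from compound 2 to compound 3 (0.36 log units; beyond the scatter), and the gap to compound 1 is of the same order, with a 2.4-fold higher number from compound 1 to compound 3 (0.39 log units; beyond the scatter). Compound 1 and compound 2 lie within the scatter of each other, as a 1.1-fold higher number from compound 1 to compound 2 (0.02 log units; within the scatter) shows.

The unmeasured compound 4, `COC(=O)CNC1=CS(=O)(=O)O[C@@]12[C@@H](CO[Si](C)(C)C(C)(C)C)O[C@@H](n1cc(C)c(=O)n(C)c1=O)[C@@H]2O[Si](C)(C)C(C)(C)C`, differs from compound 3 only in its side chain: methoxycarbonyl in place of carboxymethyl on a saturated chain carbon bound to an amine nitrogen. Read one bond further out, the change is from 2-carboxyethyl to (methoxycarbonyl)methyl on the amine nitrogen.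

The two measured steps into compound 3, a 2.4-fold higher number from compound 1 to compound 3 (0.39 log units; beyond the scatter) and a 2.3-fold higher number from compound 2 to compound 3 (0.36 log units; beyond the scatter), both record that the carboxylic acid sits at a higher number than its neutral relatives, and compound 4 carries no acid. A modest downward step in this assay is therefore expected for compound 4, giving a 2.3-fold lower number from compound 3 to compound 4 (0.36 log units; beyond the scatter). In this assay compound 4 is estimated at 15000 nM, with a range from 7000 nM to 35000 nM.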

Compound 4, half-maximal cytotoxic concentration: 160000 nM
Estimate against measurement, compound 4: 11-fold (1.03 log units) below; the whole stated range lies below it.
By their numbers in this assay, from the lowest: compounds 1 and 2 (each within the scatter of the next); then compound 3; then compound 4.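

In this assay, changes on the amine nitrogen had so far brought only modest steps, but compound 4 moves past the carboxylic acid (a 4.7-fold higher number from compound 3 to compound 4 (0.67 log units; beyond the scatter)), so among these compounds the acid does not mark the top of the series and the methyl ester, which carries no acid, shows the lowest toxicity in this test. Among the compounds shown here, the steps from the two compounds that had lain within the scatter of each other are large (an 11-fold higher number from compound 2 to compound 4 (1.03 log units; beyond the scatter); an 11-fold higher number from compound 1 to compound 4 (1.06 log units; beyond the scatter)), which shows that this position can shift the number much further than the earlier compounds showed. The change from 2-carboxyethyl to (methoxycarbonyl)methyl leaves the atoms the same and only joins them differently, so a rearrangement alone is enough for a step of this size.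

On these data alone, whether the rise follows the ester or the shorter chain stays open, and a 2-(methoxycarbonyl)ethyl group or a carboxymethyl group on the amine nitrogen would separate the two. Nothing available speaks to why the number moves at this position.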